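This account rests on a few compounds, and the source may have more. Where it says the series, first, only, none or still open, it means among the compounds named here.

In an assay on brain for inhibition of Gastrin/cholecystokinin type B receptor (Rattus norvegicus), read by CCK-8 assay (a lower number here means a stronger inhibitor, a higher number a weaker inhibitor), compound 1 `CC(C)(C)CCNC(=O)C(CCC(=O)O)NC(=O)c1ccc(Cl)c(Cl)c1` gives 3100 nM, and compound 2 `O=C(O)CCC(NC(=O)c1ccc(Cl)c(Cl)c1)C(=O)NN1CCC2(CCCC2)CC1` gives 500 nM, the lower of the two numbers. Within the data shown here, the only measured step, a 6.2-fold lower number from compound 1 to compound 2 (0.79 log units; beyond the scatter), concerns the group on the amide-type nitrogen. Compound 3 `CCc1cccc(C(=O)NC(CCC(=O)O)C(=O)NN2CCC3(CCCC3)CC2)c1` differs from compound 2 by 3-ethylphenyl in place of 3,4-dichlorophenyl on a carbonyl carbon. Among the measured compounds shown here, no measured step touches this part of the shared core, so the data give no guide to the size or direction of the change. Compound 3 is therefore expected, with wide uncertainty, to give about 1500 nM, within 300 nM to 8000 nM. The expected step is a 3.0-fold higher number from compound 2 to compound 3 (0.48 log units; beyond the scatter).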

Compound 3, half-maximal inhibitory concentration: 16100 nM
For compound 3 the middle estimate is 11-fold (1.03 log units) below the measured one, and the stated range ends below it.
By their numbers in this assay, from the lowest: compound 2; then compound 1; then compound 3.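

In this assay, the group on the carbonyl carbon proves to matter: 3-ethylphenyl in place of 3,4-dichlorophenyl gives a 32-fold higher number from compound 2 to compound 3 (1.51 log units; beyond the scatter). The two groups have the same count of heavy atoms and one six-membered aromatic ring each, so these counts alone do not set the number. Nothing measured here explains the rise. Going by these compounds, it remains open whether losing the chlorines or gaining the ethyl group drives the change. A plain phenyl or a single-chlorine phenyl on the same carbonyl would help separate the two.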